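Phenylsulfanyl in place of amino on a purine scaffold

A few compounds are considered here, and "the series" means these few. Any claim that something is new, unique, unknown or untested is made for them only; others in the source may bear on it.

Measured so far:
compound 1 `Fc1ccc(Oc2[nH]cnc3ncnc2-3)cc1`: 0%
compound 2 `Cn1cnc2c(Sc3ccccc3)ncnc21`: 8%
compound 3 `Nc1ncnc2c1ncn2Cc1ccc(F)cc1`: 9%

In an assay on isolated protein for inhibition of Ca2+/calmodulin-dependent protein kinase II (CaM kinase II) (Rattus norvegicus), tested at 30 uM (a higher number here means more inhibition at the concentration tested (going by the name of the read-out), a lower number less inhibition), compound 3 gives the highest of the three numbers, yet its gaps to compound 2 and to compound 1 both lie within the usual scatter, so no ordering among them can be claimed. Compound 4 `Fc1ccc(Cn2cnc3c(Sc4ccccc4)ncnc32)cc1` is not yet measured. Compared with compound 3 it carries phenylsulfanyl in place of amino on an aromatic carbon. Compound 2, which already carries phenylsulfanyl on its core, gives 8% in this assay, a number within the scatter of compound 3. No step beyond the scatter is therefore expected from compound 3 to compound 4, with a number 1 percentage points higher from compound 3 to compound 4 (within the scatter) as the expected change. Compound 4 is estimated at 10%, within 0% to 30%.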

Compound 4, a percentage reported as inhibition, at one concentration (the size of the read-out at that concentration, not a potency): 0%
For compound 4 the middle estimate is 10 percentage points above the measured one; the measured number falls inside the stated range.
By their numbers in this assay, from the lowest: compounds 1, 4, 2 and 3 (each within the scatter of the next).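

In this assay, putting phenylsulfanyl in place of amino on an aromatic carbon gives a number 9 percentage points lower from compound 3 to compound 4 (within the scatter), and putting 4-fluorophenyl in place of hydrogen on a saturated chain carbon bound to an aromatic nitrogen gives a number 8 percentage points lower from compound 2 to compound 4 (within the scatter). Neither change can therefore be told from no change at all, at either place on the shared core. No evidence on hand bears on this result.

From the compounds shown here alone, whether any group on that aromatic carbon can move the read-out beyond the scatter remains open. A carboxylic acid or a longer amine chain there would test this.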